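The compounds below may be only part of what the source reports. "The series", "measured", "known", "first", "only" and "open" are said of these compounds alone.

Compound 3 `CC#CC(CC(=O)O)c1ccc(OCc2ccn3cc(-c4ccccc4C)nc3c2)cc1` stands with the lowest of the three numbers in an assay on isolated protein for agonist activity at Free fatty acid receptor 1 (Homo sapiens) (on this read-out lower numbers stand for an effect already at smaller amounts and higher numbers for an effect only at larger amounts of compound), giving 459 nM; compound 2 `CC#CC(CC(=O)O)c1ccc(OCc2ccn3cc(-c4ccc(C)cc4)nc3c2)cc1` gives 618 nM and compound 1 `CC#CC(CC(=O)O)c1ccc(OCc2ccn3cc(-c4ccccc4)nc3c2)cc1` gives 1260 nM. The steps of a 2.0-fold lower number from compound 1 to compound 2 (0.31 log units; beyond the scatter) and a 2.7-fold lower number from compound 1 to compound 3 (0.44 log units; beyond the scatter) both involve methyl in place of hydrogen on an aromatic carbon, whereas a 1.3-fold lower number from compound 2 to compound 3 (0.13 log units; within the scatter) is small. Compound 4 `CC#CC(CC(=O)O)c1ccc(OCc2ccn3cc(-c4ccc(F)cc4F)nc3c2)cc1` carries 2,4-difluorophenyl in place of 2-methylphenyl on an aromatic carbon. Among the compounds with values here, no measured step swaps a methyl for fluorine or adds a second ring substituent, so the two methyl steps bear on the change only loosely. A shift no larger than the scatter, in either direction, is expected, a 1.1-fold higher number from compound 3 to compound 4 (0.04 log units; within the scatter). Compound 4 is therefore estimated at 500 nM, with a range from 200 nM to 1300 nM.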

Compound 4, half-maximal effective concentration: 792 nM
The estimate for compound 4 lay 1.6-fold (0.20 log units) below the measured number, within the range that was stated.
By their numbers in this assay, from the lowest: compounds 3, 2, 4 and 1 (each within the scatter of the next, the first and the last beyond it).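

In this assay the steps of a 1.7-fold higher number from compound 3 to compound 4 (0.24 log units; within the scatter) and a 1.3-fold higher number from compound 2 to compound 4 (0.11 log units; within the scatter) and a 1.6-fold lower number from compound 1 to compound 4 (0.20 log units; within the scatter) all lie within the scatter. The phenyl at this position, on the aromatic carbon next to the ring nitrogen, thus carries two fluorines with no step beyond the scatter from any other compound, whereas both methyl steps from compound 1 lay beyond it. Nothing at hand gives a reason for these numbers.

On these data alone, the separate share of each fluorine stays open. So does the outcome with an amine or a methoxy group on this phenyl, since only methyl and fluorine appear there.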